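The source may report more compounds than this note shows. Statements on the series, on what has been measured and on what is new or still open speak of the compounds shown alone.

Compound 1 `O=c1c(-c2nn[nH]n2)c[nH]c2c(Br)cccc12` carries a bromo group on the shared core. In a functional assay on the whole organism (strain Sprague-Dawley) for inhibition, with Rattus norvegicus as the target (on this read-out higher numbers stand for an effect only at larger amounts of compound and lower numbers for an effect already at smaller amounts), compound 1 gives only a limit, > 5 mg/kg, not a number. Compound 1 therefore sits at the limit of > 5 mg/kg in this assay, at which 1 of the 2 values shown sits. Compound 2 `COc1ccc(OC)c2c(=O)c(-c3nn[nH]n3)c[nH]c12` bears two methoxy groups, and in this assay compound 2 gives 1.25 mg/kg. Compound 3 `CC(C)Oc1cccc2c(=O)c(-c3nn[nH]n3)c[nH]c12` is still unmeasured; it differs from compound 1 in one respect: isopropoxy in place of bromo on an aromatic carbon. Going by the values given here, no measured pair separates by a single change, so the step in this assay is expected rather than known: an at least 2.0-fold lower number from compound 1 to compound 3 (0.30 log units; that floor lies within the scatter), toward a smaller dose. Compound 3 is estimated at 2.5 mg/kg, between 1 mg/kg and 10 mg/kg.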

Compound 3, minimum effective dose: 0.078 mg/kg
Beside the measured number, compound 3's estimate is 32-fold (1.51 log units) above it; measured number outside the range, below it.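

In this assay, isopropoxy in place of bromo on this aromatic carbon gives an at least 64-fold lower number from compound 1 to compound 3 (1.80 log units; beyond the scatter), so a single change at this position can move the dose required well beyond the scatter. The size of that step is only a floor, and the true gap may be larger: the limit of > 5 mg/kg in this assay, at which 1 of the 3 values shown sits.

The compounds shown leave open whether the step belongs to the oxygen link or to the branched chain. An ethoxy group, a longer butoxy chain or an amine at this position would help separate the two.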